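Methyl added to compound 3: expected dose

A few compounds are considered here, and "the series" means these few. Any claim that something is new, unique, unknown or untested is made for them only; others in the source may bear on it.

Measured so far in a functional assay on the whole organism (strain Sprague-Dawley) for inhibition, with Rattus norvegicus as the target; a lower number here means that less compound is needed, a higher number that more compound is needed for the effect:
Compound 1 `O=c1c(-c2nn[nH]n2)c[nH]c2ccccc12` gives > 20 mg/kg, a limit of the assay rather than a number.
Compound 2 `Cc1ccc2[nH]cc(-c3nn[nH]n3)c(=O)c2c1` gives > 25 mg/kg, also a limit rather than a number.
Compound 3 `O=c1c(-c2nn[nH]n2)c[nH]c2c(F)cccc12` gives 10 mg/kg.

Compound 3 thus stands as the only one of the three with a number in this assay; the other two values are limits. Its step of an at least 2.0-fold lower number from compound 1 to compound 3 (0.30 log units; that floor lies within the scatter) is read against (the limit of > 20 mg/kg in this assay, at which 1 of the 3 values shown sits), so only its floor is known. Compound 4 `Cc1cc(F)c2[nH]cc(-c3nn[nH]n3)c(=O)c2c1` differs from compound 3 as methyl in place of hydrogen on an aromatic carbon. For the measured compounds named here, the one measured step of the same kind is a step that the two limits leave unreadable from compound 1 to compound 2, and it sits between the limit of > 20 mg/kg in this assay, at which 1 of the 3 values shown sits, and (the limit of > 25 mg/kg in this assay, at which 1 of the 3 values shown sits), leaving its size and direction unreadable. Going by the values given here, no measured step therefore points either way. The change is expected to stay within the scatter, but the range is kept wide because a step that the two limits leave unreadable from compound 1 to compound 2 is unreadable and a limit remains possible. Compound 4 is estimated at 15 mg/kg, between 5 mg/kg and 40 mg/kg. The expected step is a 1.5-fold higher number from compound 3 to compound 4 (0.18 log units; within the scatter).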

Compound 4, minimum effective dose: > 10 mg/kg
Compound 4: no number, only a limit; the forecaster's own chance of this, stated with the estimate: 35%; the middle value does not contradict the limit.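

Methyl in place of hydrogen on an aromatic carbon now has a direction in this assay: a number no lower from compound 3 to compound 4 (the limit leaves the size open). This reading applies with the methyl meta to a fluoro group, and it shows that methyl at this place does not lower the number when the fluoro group is present. For the compounds shown here, compound 4 gives > 10 mg/kg, which is a limit of the assay and not a number, so compound 3 remains the only compound of the four with a number; the steps between two limits, including the fluoro step without a number on either side, cannot be read.

Going by these compounds, how far compound 4 lies from compound 3 stays open, since only the direction is bounded. Also open, on these data alone, is whether another group at this aromatic carbon, such as an amine, a methoxy group or a carboxylic acid, would give a lower number in this assay.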